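From propyl to 2-(dimethylamino)ethyl on compound 1

This account rests on a few compounds, and the source may have more. Where it says the series, first, only, none or still open, it means among the compounds named here.

Measured so far in a functional assay on SW-620 cells (Homo sapiens) for inhibition; on this read-out higher numbers stand for weaker inhibition and lower numbers for stronger inhibition

Compound 1 `CCCN1C(=O)NC2(CSC3=C2C(=O)c2ccccc2C3=O)C1=O` gives 379 nM
Compound 2 `CCC(C)N1C(=O)NC2(CSC3=C2C(=O)c2ccccc2C3=O)C1=O` gives 562 nM
Compound 3 `O=C1C2=C(C(=O)c3ccccc31)C1(CS2)NC(=O)N(CCCO)C1=O` gives 119 nM

In this assay, compound 1 cannot be told apart from its nearest neighbour, as a 1.5-fold higher number from compound 1 to compound 2 (0.17 log units; within the scatter) shows. Its furthest neighbour is a clearer gap: a 3.2-fold lower number from compound 1 to compound 3 (0.50 log units; beyond the scatter).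

The next compound, compound 4 `CN(C)CCN1C(=O)NC2(CSC3=C2C(=O)c2ccccc2C3=O)C1=O`, keeps the core of compound 1 and changes only the chain end: dimethylamino in place of methyl on a saturated chain carbon, two bonds along the chain from an amide-type nitrogen in a ring. In words, dimethylamino stands in place of methyl on a saturated chain carbon, two bonds along the chain from an amide-type nitrogen in a ring.

The closest guide is a 3.2-fold lower number from compound 1 to compound 3 (0.50 log units; beyond the scatter), where hydroxy is added on the same chain. A second step points the same way: a 4.7-fold lower number from compound 2 to compound 3 (0.67 log units; beyond the scatter). Adding only a methyl, by contrast, gave a 1.5-fold higher number from compound 1 to compound 2 (0.17 log units; within the scatter). Among the compounds with values here, neither of the two larger steps involves dimethylamino, so they are only a loose guide, and no measured compound carries that group. A modest move towards stronger inhibition is therefore expected, though a result level with compound 1 would be no surprise.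

The estimate amounts to an expected 2.2-fold lower number from compound 1 to compound 4 (0.35 log units; beyond the scatter).

For compound 4 the estimated value is 170 nM, with an expected range of 50 nM to 500 nM.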

Compound 4, half-maximal inhibitory concentration: 57 nM
Compound 4: the middle estimate sits 3.0-fold (0.47 log units) above what was measured; low and high end bracket the measured number.
By their numbers in this assay, from the lowest: compound 4; then compound 3; then compounds 1 and 2 (each within the scatter of the next).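

In this assay, dimethylamino at the end of the chain gives the largest step yet seen from compound 1 (a 6.6-fold lower number from compound 1 to compound 4 (0.82 log units; beyond the scatter)), so this position can deliver more than the hydroxy of compound 3 had shown. The two chain ends can also be told apart (a 2.1-fold lower number from compound 3 to compound 4 (0.32 log units; beyond the scatter)), which means that the identity of the group at the chain end matters, and not only that the plain carbon chain has been changed. The widest gap among the compounds shown separates the sec-butyl compound from the new one (a 9.9-fold lower number from compound 2 to compound 4 (0.99 log units; beyond the scatter)), and all four compounds fit one simple pattern: the two chains ending in hydroxy or dimethylamino give lower numbers than the two plain carbon chains, though no measurement here explains why.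

The compounds shown leave open whether the two methyl groups on the nitrogen are needed, which a primary amine or a pyrrolidine ring at the chain end would address. They also leave open how the result depends on chain length, as a longer chain such as 3-(dimethylamino)propyl would show, and how a carboxylic acid at the same chain end would compare.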